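Shifting a Hydroxyl Around an Aryl Ring: Cytotoxicity

A few compounds are considered here, and "the series" means these few. Any claim that something is new, unique, unknown or untested is made for them only; others in the source may bear on it.

Compound 1 `Oc1cccc(-c2cc(-c3ccccc3O)nc(-c3ccccc3O)c2)c1` is tested in an ADME assay on HEK293 cells (Homo sapiens) for cytotoxicity, read by CCK-8 assay, with a stated time of 4 days (a lower number here means a stronger inhibitor, a higher number a weaker inhibitor), where compound 1 gives 80 nM. Compound 2 `Oc1ccc(-c2cc(-c3ccccc3O)nc(-c3ccccc3O)c2)cc1` differs by 4-hydroxyphenyl in place of 3-hydroxyphenyl on an aromatic carbon. In this assay compound 2 gives only a limit of the assay, > 50000 nM. The step is an at least 620-fold higher number from compound 1 to compound 2 (2.79 log units; beyond the scatter). Compound 3 `Oc1ccc(-c2cc(-c3cccc(O)c3)nc(-c3ccccc3O)c2)cc1` is another arrangement of the same atoms; how its core differs from that of compound 1 is not broken down here. In this assay compound 3 gives 7420 nM. The step of an at least 6.7-fold lower number from compound 2 to compound 3 (0.82 log units; beyond the scatter) rests on a limit (the limit of > 50000 nM in this assay, at which 1 of the 3 values shown sits). Compound 4 `Oc1ccc(-c2cc(-c3ccc(O)cc3)nc(-c3ccccc3O)c2)cc1` is not yet measured and differs from compound 3 by 4-hydroxyphenyl in place of 3-hydroxyphenyl on an aromatic carbon. This is the same kind of change as from compound 1 to compound 2, but the place differs: here it is next to the ring nitrogen and meta to a 2-hydroxyphenyl group and a 4-hydroxyphenyl group, rather than opposite the ring nitrogen and meta to two 2-hydroxyphenyl groups. Compound 4 is expected to show a 4.0-fold higher number from compound 3 to compound 4 (0.61 log units; beyond the scatter) in this assay because the step of an at least 620-fold higher number from compound 1 to compound 2 (2.79 log units; beyond the scatter) was large. Compound 4 is estimated at 30000 nM, between 7000 nM and 100000 nM.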

Compound 4, half-maximal inhibitory concentration: 26300 nM
Beside the measured number, compound 4's estimate is 1.1-fold (0.06 log units) above it; the measured number falls inside the stated range.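

In this assay, putting 4-hydroxyphenyl in place of 3-hydroxyphenyl gives a higher number on both cores, but the size of the step does not carry over: the same change on two cores in this assay, an at least 620-fold higher number (2.79 log units; beyond the scatter) from compound 1 to compound 2 and a 3.5-fold higher number (0.55 log units; beyond the scatter) from compound 3 to compound 4, at least 170-fold (2.24 log units) apart, beyond the scatter of two such steps. On the core of compound 3 the step is only a 3.5-fold higher number from compound 3 to compound 4 (0.55 log units; beyond the scatter), so the direction held and the size did not, and two cores cannot show what the change would do on a third. The step of an at least 1.9-fold lower number from compound 2 to compound 4 (0.27 log units; that floor lies within the scatter) cannot be read as a real difference, since the value of compound 2 is a limit: the limit of > 50000 nM in this assay, at which 1 of the 4 values shown sits.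

The compounds shown carry only hydroxyphenyl groups on the shared core. On these data alone, what a methoxyphenyl group, an aminophenyl group or a carboxylic acid would do there stays open.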